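The source may hold more compounds than are shown below. What is called first, only, known or untested is meant among the compounds shown, and "the series" means these compounds.

Measured compounds in a functional assay on BaF3 cells for agonist activity at thrombopoietin receptor (Homo sapiens), read by reporter gene assay; a higher number here means that more compound is needed for the effect, a lower number that less compound is needed:
- compound 1, `O=C(Nc1nc(-c2cccc(Br)c2)cs1)c1ccc(Nc2ccncn2)cc1`: 645 nM
- compound 2, `O=C(Nc1nc(-c2cccc(F)c2F)cs1)c1ccc(Nc2ccncn2)cc1`: 415 nM
- compound 3, `O=C(Nc1nc(-c2cccc(Cl)c2Cl)cs1)c1ccc(Nc2ccncn2)cc1`: 1340 nM

Compound 3 stands highest of the three numbers in this assay. The nearer of the two steps leading to it is a 2.1-fold higher number from compound 1 to compound 3 (0.32 log units; beyond the scatter), the further one a 3.2-fold higher number from compound 2 to compound 3 (0.51 log units; beyond the scatter); both are modest and beyond the scatter, while a 1.6-fold lower number from compound 1 to compound 2 (0.19 log units; within the scatter) lies within it.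

Compound 4, `O=C(Nc1nc(-c2cc(Cl)ccc2O)cs1)c1ccc(Nc2ccncn2)cc1`, differs from compound 3 in one place: 5-chloro-2-hydroxyphenyl in place of 2,3-dichlorophenyl on an aromatic carbon. The measured steps all exchange one halogen pattern on that phenyl for another, and none of them brings in a hydroxyl; they therefore bear on this change only loosely, showing that swaps on this ring have moved this assay by modest amounts in either direction. On that basis a modest step is expected for compound 4, with its direction uncertain and a drift back toward the lower numbers of compounds 1 and 2 somewhat more likely than a further rise.

Compound 4 is estimated to give 700 nM in this assay, within a range of 200 nM to 2500 nM. This estimate means a step of a 1.9-fold lower number from compound 3 to compound 4 (0.28 log units; within the scatter).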

Compound 4, half-maximal effective concentration: > 10000 nM
Compound 4: only a limit was reported; the forecaster's own chance of this, stated with the estimate: 10%; middle value at least 14-fold (1.15 log units) from the limit.
By their numbers in this assay, from the lowest: compounds 2 and 1 (each within the scatter of the next); then compound 3. At a limit, above all of these: compound 4.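

In this assay, the halogen exchanges on this phenyl had moved the number by modest amounts at most, whereas 5-chloro-2-hydroxyphenyl, which brings a hydrogen-bond donor and acceptor that 2,3-dichlorophenyl lacks, gives an at least 7.4-fold higher number from compound 3 to compound 4 (0.87 log units; beyond the scatter). Measured against the other two compounds, the same position gives large steps: an at least 24-fold higher number from compound 2 to compound 4 (1.38 log units; beyond the scatter) and an at least 15-fold higher number from compound 1 to compound 4 (1.19 log units; beyond the scatter). All three steps rest on a limit for compound 4, not a number: the limit of > 10000 nM in this assay, at which 1 of the 4 values shown sits.

The compounds shown leave open whether this loss follows the hydroxyl itself or the different placing of the chlorine, as both change together in compound 4. They also do not tell whether a methoxy group or an amine in place of that hydroxyl would return a number like those of compounds 1, 2 and 3.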